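Terminal substituent of the carbamate chain: compound 3 to compound 4

The compounds below may be only part of what the source reports. "The series", "measured", "known", "first", "only" and "open" are said of these compounds alone.

Measured so far in a functional assay on H4 cells with growth hormone secretagogue receptor type 1 (Homo sapiens) as the target, read by FLIPR; a lower number here means that less compound is needed, a higher number that more compound is needed for the effect:
compound 1, `CC(C)(N)C(=O)N[C@H](COCc1ccccc1)c1nnnn1CCOC(=O)NCCCO`, 5.5 nM
compound 2, `CC(C)(N)C(=O)N[C@H](COCc1ccccc1)c1nnnn1CCOC(=O)NCCCCCO`, 14.6 nM
compound 3, `CC(=O)NCCCCNC(=O)OCCn1nnnc1[C@@H](COCc1ccccc1)NC(=O)C(C)(C)N`, 82.5 nM

Compound 3 stands highest of the three numbers in this assay. Its nearest neighbour is compound 2, a 5.7-fold higher number from compound 2 to compound 3 (0.75 log units; beyond the scatter), and the gap to compound 1 is wider still, a 15-fold higher number from compound 1 to compound 3 (1.18 log units; beyond the scatter). The two steps that lead to it both replace the terminal hydroxy end of the chain with something longer: a 2.7-fold higher number from compound 1 to compound 2 (0.42 log units; beyond the scatter) and a 15-fold higher number from compound 1 to compound 3 (1.18 log units; beyond the scatter).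

Compound 4, `CC(C)(N)C(=O)N[C@H](COCc1ccccc1)c1nnnn1CCOC(=O)NCCCn1ccnc1`, is not yet measured. It differs from compound 3 as follows: 1H-imidazol-1-yl in place of acetamidomethyl on a saturated chain carbon, three bonds along the chain from an amide-type nitrogen. Within the data shown here, no measured step carries this exact change. Among the measured compounds shown here, the step that comes closest is the one from compound 2 to compound 3, where a terminal hydroxymethyl gives way to acetamido; the change to compound 4 goes the other way in chain length, back toward the shorter terminus of compound 2, while the donor at the end is lost. The measured steps all moved upward on lengthening, so a return toward a shorter end is expected to bring the number down, though the loss of the donor leaves the size uncertain. For compound 4 a modest lower number is therefore expected, a 2.8-fold lower number from compound 3 to compound 4 (0.44 log units; beyond the scatter), with an estimate of 30 nM in this assay, within 8 nM to 120 nM.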

Compound 4, half-maximal effective concentration: 45.3 nM
For compound 4 the middle estimate is 1.5-fold (0.18 log units) below the measured one, within the range that was stated.
By their numbers in this assay, from the lowest: compound 1; then compound 2; then compounds 4 and 3 (each within the scatter of the next).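

In this assay, 1H-imidazol-1-yl in place of acetamidomethyl gives a 1.8-fold lower number from compound 3 to compound 4 (0.26 log units; within the scatter), so at this chain end a five-membered aromatic ring without a hydrogen-bond donor cannot be told apart from the acetamido terminus of compound 3. The hydroxy-ended compounds remain separate: the direct swap on the same saturated chain carbon, three bonds along the chain from an amide-type nitrogen, gives an 8.2-fold higher number from compound 1 to compound 4 (0.92 log units; beyond the scatter), and the comparison with the longer hydroxy chain gives a 3.1-fold higher number from compound 2 to compound 4 (0.49 log units; beyond the scatter). The lowest numbers among these compounds therefore stay with the two hydroxy termini, and no evidence shown here accounts for these steps.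

On these data alone, it remains open whether a primary amine or a carboxylic acid at this chain end would group with compound 1 or with compound 3 and compound 4. Also open, as far as these compounds go, is whether a longer chain carrying 1H-imidazol-1-yl would move the number as lengthening did among the hydroxy compounds, where the step is a 2.7-fold higher number from compound 1 to compound 2 (0.42 log units; beyond the scatter).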